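The source may report more compounds than this note shows. Statements on the series, on what has been measured and on what is new or still open speak of the compounds shown alone.

Three compounds have been examined in an ADME assay on microsomes from liver (Mus musculus) for metabolic stability, read by LC-MS, with NADPH named in the record, with a stated time of 60 min, tested at 1 uM, in the absence of a further agent; on this read-out lower numbers stand for a less stable compound and higher numbers for a more stable compound. Compound 1 `COc1ccc(-n2c(C)nc3c(N4CC[C@@H](NC(C)=O)C4)nc(C)nc32)cc1OC` returns only a limit of the assay, > 95%. Compound 2 `CSc1ccc(-c2c(C)nc3c(N4CC[C@@H](NC(C)=O)C4)cc(C)nn23)cc1` likewise sits at that limit, > 95%. Compound 3 `COc1ccc(-c2c(C)nc3c(N4CC[C@@H](NC(=O)c5ccccc5)C4)cc(C)nn23)cc1OC` also reaches the limit, > 95%. Compound 3 thus stands where every measured compound stands, at the limit of > 95% in this assay, at which 3 of the 3 values shown sit, and no numbered step between measured compounds can be drawn from these values. Compound 4 `COc1ccc(-c2c(C)nc3c(N4CC[C@@H](NS(=O)(=O)c5ccccc5)C4)cc(C)nn23)cc1OC` has not yet been measured. It differs from compound 3 in one place: phenylsulfonyl in place of benzoyl on an amine nitrogen. For the measured compounds named here, no measured step shows how this assay responds to such a change on an amine nitrogen, and three values at the limit give no measure of how far any change could move the read-out before it leaves that limit. In this assay the step is expected to be small, or none beyond the scatter, and is estimated as a number at least 3 percentage points lower from compound 3 to compound 4 (that floor lies within the scatter). Compound 4 is expected to give about 92% in this assay, between 78% and 99%.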

Compound 4, percent of the compound remaining: > 95%
Compound 4 gave a limit, no number; the forecaster's own chance of this, stated with the estimate: 65%; middle value at least 3 percentage points away from the limit.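

In this assay, for the compounds shown here, compound 4 returns only a limit, > 95%, so no step between compound 3 and compound 4 can be read. The compounds shown leave open how far any change, phenylsulfonyl in place of benzoyl included, could move this read-out: the limit of > 95% in this assay, at which 4 of the 4 values shown sit.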